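A few compounds are considered here, and "the series" means these few. Any claim that something is new, unique, unknown or untested is made for them only; others in the source may bear on it.

Measured compounds:
Compound 1 `O=C1CCC(=O)N1Cc1cc2nccc(-c3cc(Cl)cc4c3O[C@@H](c3onc5c3CNCC5)C4)c2s1` — in an ADME assay on the whole organism (Rattus norvegicus, strain Sprague-Dawley) for pharmacokinetics, at a dose of 0.5 mg/kg by the intravenous route (a lower number here means slower removal, a higher number faster removal of the compound), compound 1 gives 96.7 mL/min/kg.
Compound 2 `Cc1cc(Cl)cc(-c2ccnc3cc(CN4C(=O)CCC4=O)sc23)c1O[C@H]1CCCNC1` — in this assay compound 2 gives 81.7 mL/min/kg.
Compound 3 `O=C1CCC(=O)N1Cc1cc2nccc(-c3cc(Cl)cc4c3O[C@@H](c3ocnc3CN3CCC3)C4)c2s1` — in this assay compound 3 gives "not determined" (no result reported), that is, no result was reported.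

Compound 3 therefore stands nowhere on the numbers: no clearance value exists for it, and whatever is said of the step to compound 4 cannot lean on a measured starting point. Compound 4 `Cn1nc2c(c1[C@H]1Cc3cc(Cl)cc(-c4ccnc5cc(CN6C(=O)CCC6=O)sc45)c3O1)CNCC2` differs from compound 3 by a group of 10 heavy atoms (7 carbon, 3 nitrogen; one five-membered aromatic ring with 2 hetero atoms, one six-membered non-aromatic ring with 1 hetero atom) in place of a group of 10 heavy atoms (7 carbon, 2 nitrogen, 1 oxygen; one four-membered non-aromatic ring with 1 hetero atom, one five-membered aromatic ring with 2 hetero atoms), on a saturated ring carbon. Among the compounds with values here, no step between measured compounds is available, so the size of this change cannot be read from a matched pair. Within the data shown here, the only guide is that compound 1 and compound 2, which share the core with compound 4 and carry a ring bearing one hydrogen-bond donor at the same region, both show clearance values close to each other. Compound 4 is expected to sit in that same region, with no expected shift beyond the scatter. In this assay compound 4 is estimated at 85 mL/min/kg, with a range from 45 mL/min/kg to 160 mL/min/kg, because compound 1 gives 96.7 mL/min/kg with a closely related group.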

Compound 4, clearance: 78.3 mL/min/kg
Compound 4: middle estimate off by 1.1-fold (0.04 log units), on the high side; measured number inside the range.
By their numbers in this assay, from the lowest: compounds 4, 2 and 1 (each within the scatter of the next).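

In this assay, a swap on the saturated ring carbon next to the ring oxygen, between two groups that each hold a five-membered aromatic ring with 2 hetero atoms and a six-membered non-aromatic ring with 1 hetero atom, gives a 1.2-fold lower number from compound 1 to compound 4 (0.09 log units; within the scatter), so this exchange does not separate the two compounds on clearance. The step from compound 3 to compound 4 cannot be read, which leaves the 4-((azetidin-1-yl)methyl)-1,3-oxazol-5-yl group without a comparison at this position. No supporting data bear on this result.

From the compounds shown here alone, it remains open whether any group at this carbon would give a clearance outside the scatter of these values. Neither a carboxylic acid nor a simple open-chain amine is among the compounds shown, so their effect at this position is unknown.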